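Notes on replacing the 3,4-dichlorophenyl of compound 2

The source may report more compounds than this note shows. Statements on the series, on what has been measured and on what is new or still open speak of the compounds shown alone.

Values in a functional assay on HT-29 cells (Homo sapiens); a higher number here means a weaker inhibitor of growth, a lower number a stronger inhibitor of growth
compound 1 `O=S(=O)(/C=C/c1ccc(Cl)c(Cl)c1)Cc1ccc(Nc2ncnc3ccccc23)cc1` gives 11000 nM
compound 2 `O=S(=O)(/C=C/c1ccc(Cl)c(Cl)c1)Cc1ccc(Nc2ncnc3ccc(Br)cc23)cc1` gives 27000 nM

For the measured compounds named here, compound 2 holds the higher of the two numbers, and a 2.5-fold higher number from compound 1 to compound 2 (0.39 log units; beyond the scatter) is the only measured step. Compound 3 `O=S(=O)(/C=C/c1ccc(F)cc1F)Cc1ccc(Nc2ncnc3ccc(Br)cc23)cc1` carries this change: 2,4-difluorophenyl in place of 3,4-dichlorophenyl on a double-bonded chain carbon bound to a double-bonded chain carbon. The measured step is a bromo in place of hydrogen on an aromatic carbon, elsewhere in the structure, so it bears only as a guide to scale. Going by the values given here, no measured step covers the new change, and no shift beyond the scatter is expected. The expected step is a 1.4-fold lower number from compound 2 to compound 3 (0.13 log units; within the scatter). For compound 3 the estimated value is 20000 nM, with an expected range of 6000 nM to 60000 nM.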

Compound 3, concentration for 50% growth inhibition: 100000 nM
Beside the measured number, compound 3's estimate is 5.0-fold (0.70 log units) below it, and the stated range ends below it.
By their numbers in this assay, from the lowest: compound 1; then compound 2; then compound 3.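

Replacing 3,4-dichlorophenyl with 2,4-difluorophenyl on a double-bonded chain carbon bound to a double-bonded chain carbon gives a 3.7-fold higher number from compound 2 to compound 3 (0.57 log units; beyond the scatter) in this assay and so weakens growth inhibition. The earlier step lay elsewhere in the structure, whereas this one shows that the aryl group at this position affects the read-out even when heavy-atom, donor and acceptor counts stay the same. Nothing available explains the step.

Compound 3 changes both the halogen and its ring placement, leaving their separate contributions unresolved. A 3,4-difluorophenyl or 2,4-dichlorophenyl group would separate the two.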